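The compounds below may be only part of what the source reports. "The series", "measured", "known", "first", "only" and "open" are said of these compounds alone.

Measured in an ADME assay on HeLa cells (Homo sapiens) for cytotoxicity, read by crystal violet staining, with a stated time of 72 h; on this read-out higher numbers stand for lower toxicity in this test and lower numbers for higher toxicity in this test:
- compound 1 `COC(=O)c1cc(CCCOc2c(C)cc(-c3noc(C(F)(F)F)n3)cc2C)on1`: 35400 nM
- compound 2 `CCOC(=O)c1cc(CCCOc2ccc(-c3noc(C(F)(F)F)n3)cc2)on1`: > 100000 nM

Among the compounds with values here, compound 1 holds the only actual number in this assay, at 35400 nM. For compound 2, the reading of > 100000 nM is a limit of the assay and not a number. The two compounds differ in more than one place, so their readings isolate no single structural change.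

Compound 3 `CCNC(=O)c1cc(CCCOc2c(C)cc(-c3noc(C(F)(F)F)n3)cc2C)on1` keeps the core of compound 1 and carries ethylamino in place of methoxy on a carbonyl carbon. The change turns 3-(methoxycarbonyl)-1,2-oxazol-5-yl into 3-(ethylcarbamoyl)-1,2-oxazol-5-yl. Within the data shown here, no measured pair shows this change, so the expectation is anchored only on compound 1 at 35400 nM and remains loose. The expected 1.4-fold higher number from compound 1 to compound 3 (0.15 log units; within the scatter) is small, points toward lower toxicity and stays within the usual scatter. The reading may also end at the assay limit rather than as a number. For compound 3 the estimated value is 50000 nM, with an expected range of 18000 nM to 100000 nM.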

Compound 3, half-maximal cytotoxic concentration: > 100000 nM
Compound 3: only a limit was reported; the forecaster's own chance of this, stated with the estimate: 35%; middle value at least 2.0-fold (0.30 log units) from the limit.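

Ethylamino in place of methoxy on a carbonyl carbon gives the first step in this series that can be read at a single place: in this assay it is an at least 2.8-fold higher number from compound 1 to compound 3 (0.45 log units; beyond the scatter), in the direction of lower toxicity in this test. Compound 3 reads > 100000 nM, which is a limit of the assay and not a number. The step therefore fixes a direction and a minimum size only, and its full size stays unknown because the reading stops at the end of the scale: the limit of > 100000 nM in this assay, at which 2 of the 3 values shown sit.

Open, as far as these compounds go, is which part of the change goes with the step, the amide hydrogen or the ethyl chain, and a dimethylamino group or a carboxylic acid on the same carbonyl carbon would help separate these. Within the data shown here, also open is whether the exchange of 3-(methoxycarbonyl)-1,2-oxazol-5-yl for 3-(ethylcarbamoyl)-1,2-oxazol-5-yl acts the same way on other cores, since the series holds only this one pair that differs in one place.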